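The source may hold more compounds than are shown below. What is called first, only, known or untested is meant among the compounds shown, and "the series" means these compounds.

Working notes on the series. Among the compounds with values here, compound 1 `CCOC(=O)c1cccc(-c2n[nH]c3ccccc23)c1` and compound 2 `CCOC(=O)c1ccc(-c2nn(C)c3ccccc23)cc1` are the only measured members so far. In a functional assay on cells (Platelet, Homo sapiens) for inhibition (on this read-out higher numbers stand for weaker inhibition and lower numbers for stronger inhibition), compound 1 reads > 10000 nM, which is a limit and not a number. Compound 2 reads > 10000 nM, also a limit. Within the data shown here, the record therefore holds only (the limit of > 10000 nM in this assay, at which 2 of the 2 values shown sit), and compound 2 marks no more than a floor of the series, with no measured step to size what follows.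

Compound 3 `CCOC(=O)c1ccc(-c2nn(Cc3ccccc3Cl)c3ccccc23)cc1` carries one change from compound 2: 2-chlorophenyl in place of hydrogen on a saturated chain carbon bound to an aromatic nitrogen, which reads as methyl to 2-chlorobenzyl, on a saturated chain carbon bound to an aromatic nitrogen. This is a large addition, and stronger inhibition in this assay is expected, beyond the scatter, though the size is uncertain. The expected step is an at least 6.6-fold lower number from compound 2 to compound 3 (0.82 log units; beyond the scatter). The estimate for compound 3 is 1500 nM, with an expected range of 200 nM to 10000 nM.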

Compound 3, half-maximal inhibitory concentration: > 10000 nM
Compound 3 gave a limit, no number; the forecaster's own chance of this, stated with the estimate: 30%; middle value at least 6.6-fold (0.82 log units) from the limit.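

Compound 3 reads > 10000 nM, again a limit and not a number, so no step can be read from compound 2 to compound 3. The compounds shown leave open whether 2-chlorobenzyl in place of methyl changes inhibition at all, with every value at one limit: the limit of > 10000 nM in this assay, at which 3 of the 3 values shown sit.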